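This account rests on a few compounds, and the source may have more. Where it says the series, first, only, none or still open, it means among the compounds named here.

This account follows the step from compound 1 `CCCCCNc1nc(NCc2ccco2)c2cc(F)ccc2n1` to compound 4 `COc1ccc(Nc2nc(NCc3ccco3)c3cc(F)ccc3n2)cc1`. In a functional assay on HT-29 cells (Homo sapiens) for cytotoxicity, read by MTT assay, with a stated time of 2 days, tested at 10 uM (a lower number here means less inhibition, a higher number more inhibition at the concentration tested (going by the name of the read-out)), compound 1 stands without a number: its entry reads "not determined" (no result reported). Compound 3 `CCCCCNc1nc(NCc2ccco2)c2ccccc2n1`, which shares the core, is in the same position, with "not determined" (no result reported). Among the compounds with values here, the only numerical anchor is compound 2 `Cc1cccc(N2CCN(CCCNc3nc(NCc4ccco4)c4cc(F)ccc4n3)CC2)c1C`, which in this assay gives 96.7%. The change from compound 1 to compound 4 is 4-methoxyphenyl in place of pentyl on a nitrogen on an aromatic ring. Within the data shown here, no measured pair shows this step, so neither its size nor its direction can be read from the data; one expects compound 4 to land high, since compound 2 reaches 96.7% with a different group on the nitrogen on the aromatic ring. Compound 4 is estimated at 70%, expected to fall between 30% and 98%.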

Compound 4, a percentage reported as inhibition, at one concentration (the size of the read-out at that concentration, not a potency): 86.2%
Estimate against measurement, compound 4: 16.2 percentage points below; the measured number falls inside the stated range.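

Within the data shown here, the result for compound 4 yields no new step from compound 1 in this assay. What replacing pentyl with 4-methoxyphenyl does to inhibition stays open, and no evidence shown bears on the value of compound 4.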